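Fluoro-to-hydrogen step in a phenylpropanoic acid series

A few compounds are considered here, and "the series" means these few. Any claim that something is new, unique, unknown or untested is made for them only; others in the source may bear on it.

Measured so far:
compound 1 `O=C(O)CCc1ccc(C#CC2=CCCCC2)cc1`: 100%
compound 2 `C=C(C)C#Cc1ccc(CCC(=O)O)c(F)c1`: 106%

In a functional assay on 1321-N1 cells for agonist activity at Free fatty acid receptor 1 (Homo sapiens), read by calcium flux, with a stated time of 0.4 s (a lower number here means a smaller maximal response, a higher number a larger maximal response), compound 2 gives 106%, the larger of the two numbers, but compound 1 at 100% lies within the scatter, so the two are not separated. Compound 3 `C=C(C)C#Cc1ccc(CCC(=O)O)cc1` differs from compound 2 by hydrogen in place of fluoro on an aromatic carbon. Within the data shown here, no measured pair shows such a change, and with both known compounds near the control level, no step beyond the scatter is expected in either direction. Compound 3 is therefore estimated at 100% (range 85% to 115%), an expected step of a number 6 percentage points lower from compound 2 to compound 3 (within the scatter).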

Compound 3, largest response reached (reported as efficacy), in percent of the reference or control that the assay uses: 108%
Compound 3: middle estimate off by 8 percentage points, on the low side, and the stated range covers the measured number.
By their numbers in this assay, from the lowest: compounds 1, 2 and 3 (each within the scatter of the next).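

In this assay, hydrogen in place of fluoro on the aromatic carbon ortho to a 2-carboxyethyl group gives a number 2 percentage points higher from compound 2 to compound 3 (within the scatter) and so leaves the two substituents unseparated at this position. 1-Methylethenyl in place of cyclohex-1-en-1-yl on a triple-bonded carbon gives a number 8 percentage points higher from compound 1 to compound 3 (within the scatter) and likewise separates neither group from the other. Nothing available explains either result.

Open, as far as these compounds go, is whether a chloro or methoxy group on that aromatic carbon would shift the maximal response beyond the scatter. Also open, from the compounds shown here alone, is how a longer chain in place of the 2-carboxyethyl group would read.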